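Extending the hydroxyalkyl chain on a chemokine receptor antagonist

The source may report more compounds than this note shows. Statements on the series, on what has been measured and on what is new or still open speak of the compounds shown alone.

Compound 1 `CNc1nccnc1-c1cc(Cl)ccc1NS(=O)(=O)c1ccc(C(C)(C)C)cc1`: 25 nM
Compound 2 `CC(C)(C)c1ccc(S(=O)(=O)Nc2ccc(Cl)cc2-c2nccnc2NCCO)cc1`: 34 nM

In a functional assay on isolated protein for antagonist activity at C-C chemokine receptor type 9 (Homo sapiens), read by calcium flux, with a stated time of 10 min (a lower number here means a stronger inhibitor, a higher number a weaker inhibitor), compound 2 stands highest of the two numbers, yet its gap to compound 1 lies within the scatter, so neither is set apart. Compound 3 `CC(C)(C)c1ccc(S(=O)(=O)Nc2ccc(Cl)cc2-c2nccnc2NCCCO)cc1` carries hydroxymethyl in place of hydroxy on a saturated chain carbon, two bonds along the chain from a nitrogen on an aromatic ring. Among the measured compounds shown here, the one measured step bears directly on this change because a 1.4-fold higher number from compound 1 to compound 2 (0.13 log units; within the scatter) added the same group to the same chain and stayed within the scatter. Compound 3 is therefore expected to show a 1.2-fold higher number from compound 2 to compound 3 (0.07 log units; within the scatter), no shift beyond the scatter in this assay. For compound 3 the estimate in this assay is 40 nM, with a range from 15 nM to 110 nM.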

Compound 3, half-maximal inhibitory concentration: 614 nM
Beside the measured number, compound 3's estimate is 15-fold (1.19 log units) below it; measured number outside the range, above it.
By their numbers in this assay, from the lowest: compounds 1 and 2 (each within the scatter of the next); then compound 3.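

In this assay the chain on this nitrogen proves far less forgiving than the first extension suggested: hydroxymethyl in place of hydroxy gives an 18-fold higher number from compound 2 to compound 3 (1.26 log units; beyond the scatter) and so stands apart from the earlier step. Set against the hydrogen of the shorter chain, 2-hydroxyethyl gives a 25-fold higher number from compound 1 to compound 3 (1.39 log units; beyond the scatter) and confirms that the loss appears only at the 3-hydroxypropyl length. Nothing at hand explains this sharp turn. Still open, as far as these compounds go, is whether the chain length alone matters or the terminal hydroxy does too. A propyl chain ending in methoxy, an amine or a carboxylic acid could separate the two, and a 4-hydroxybutyl chain would show whether the trend continues.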